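A few compounds are considered here, and "the series" means these few. Any claim that something is new, unique, unknown or untested is made for them only; others in the source may bear on it.

In a functional assay on HL-60 cells (Homo sapiens) for cytotoxicity, read by CCK-8 assay, with a stated time of 24 h (on this read-out lower numbers stand for stronger inhibition and higher numbers for weaker inhibition), three compounds sharing one core have been measured. Compound 1 `C=CC(=O)N1C(=O)CC(C)Sc2ccccc21`, carrying methyl, gives 199000 nM. Compound 2 `C=CC(=O)N1C(=O)CC(c2ccc(Cl)cc2)Sc2ccccc21`, carrying 4-chlorophenyl, gives 95700 nM. Compound 3 `C=CC(=O)N1C(=O)CC(c2cccs2)Sc2ccccc21`, carrying thiophen-2-yl, gives 695000 nM, the highest number of the three and so the weakest inhibition. Compound 4 `C=CC(=O)N1C(=O)CC(c2cccc(Cl)c2)Sc2ccccc21` has not been measured. It has 3-chlorophenyl in place of thiophen-2-yl on a saturated ring carbon. The closest guide is a 7.3-fold higher number from compound 2 to compound 3 (0.86 log units; beyond the scatter), a modest step that thiophen-2-yl brought when it replaced 4-chlorophenyl. Read backwards, it points to a lower number in this assay, although no measurement yet compares 3-chlorophenyl with 4-chlorophenyl. The expected change is a 5.8-fold lower number from compound 3 to compound 4 (0.76 log units; beyond the scatter). For compound 4 the estimated value is 120000 nM, with an expected range of 45000 nM to 320000 nM.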

Compound 4, half-maximal inhibitory concentration: 93100 nM
For compound 4 the middle estimate is 1.3-fold (0.11 log units) above the measured one; the measured number falls inside the stated range.
By their numbers in this assay, from the lowest: compounds 4 and 2 (each within the scatter of the next); then compound 1; then compound 3.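

Swapping 4-chlorophenyl for 3-chlorophenyl on this saturated ring carbon leaves the number unchanged within the scatter, with a 1.0-fold lower number from compound 2 to compound 4 (0.01 log units; within the scatter), so the two chlorophenyl groups cannot be told apart here. The second chlorophenyl group also repeats the gains seen with the first: 3-chlorophenyl in place of thiophen-2-yl gives a 7.5-fold lower number from compound 3 to compound 4 (0.87 log units; beyond the scatter), and in place of methyl it gives a 2.1-fold lower number from compound 1 to compound 4 (0.33 log units; beyond the scatter).

From the compounds shown here alone, how an amine or a carboxylic acid would compare at this carbon remains open. The compounds shown also offer no measured explanation for these differences.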